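Benzyl ether variation on the shared core

A few compounds are considered here, and "the series" means these few. Any claim that something is new, unique, unknown or untested is made for them only; others in the source may bear on it.

Measured in an assay on CHO cells for displacement of a labelled ligand from Alpha-1A adrenergic receptor (Homo sapiens); a higher number here means a weaker inhibitor, a lower number a stronger inhibitor:
compound 1, `COc1cccc(OC)c1OCCNCCOc1ccccc1OCc1ccccc1[N+](=O)[O-]`: 7.94 nM
compound 2, `COc1cccc(OC)c1OCCNCCOc1ccccc1OCc1ccc([N+](=O)[O-])cc1`: 1.26 nM

For the measured compounds named here, compound 2 holds the lower of the two numbers; its nearest neighbour is compound 1, and the only step in the set is a 6.3-fold lower number from compound 1 to compound 2 (0.80 log units; beyond the scatter), a change in the position of the nitro group alone. Compound 3 is `COc1cccc(COc2ccccc2OCCNCCOc2c(OC)cccc2OC)c1`, reached from compound 2 by 3-methoxyphenyl in place of 4-nitrophenyl on a saturated chain carbon bound to an oxygen on an aromatic ring. Going by the values given here, the single measured step bears on this only loosely: it shows that the substitution pattern of the ring on the benzyl ether moves this assay by a modest amount, but no measured pair exchanges a nitro group for a methoxy group, and none carries the methoxy group at this place. Among the compounds with values here, the change in compound 3 is therefore two moves at once, a new group and a new ring position, with no direct precedent. A modest rise in this assay is expected, with wide uncertainty, and the step is estimated as a 2.5-fold higher number from compound 2 to compound 3 (0.40 log units; beyond the scatter). For compound 3 the estimate is 3.2 nM, with a range of 0.8 nM to 13 nM.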

Compound 3, inhibition constant: 2 nM
Estimate against measurement, compound 3: 1.6-fold (0.20 log units) above; the measured number falls inside the stated range.
By their numbers in this assay, from the lowest: compounds 2 and 3 (each within the scatter of the next); then compound 1.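

In this assay, the exchange of 4-nitrophenyl for 3-methoxyphenyl on a saturated chain carbon bound to an oxygen on an aromatic ring gives a 1.6-fold higher number from compound 2 to compound 3 (0.20 log units; within the scatter), so a nitro group is not required for a number in the range of compound 2, and a new group with a new ring position can be accepted here without a step beyond the scatter. The exchange of 2-nitrophenyl for the same group gives a 4.0-fold lower number from compound 1 to compound 3 (0.60 log units; beyond the scatter), which leaves compound 1 as the only one of the three set apart, with steps beyond the scatter to both others, and so the separation seen earlier is not a simple matter of having or lacking a nitro group. No supporting measurement bears on why the three groups fall in this way.

Group and ring position change together in the step to compound 3, so their separate contributions remain unresolved, and a single methoxy-bearing compound gives no view of how this group behaves elsewhere on the ring. Also open, from the compounds shown here alone, is how this position responds to an unsubstituted phenyl ring, or to a ring carrying an amine or a carboxylic acid.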